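A few compounds are considered here, and "the series" means these few. Any claim that something is new, unique, unknown or untested is made for them only; others in the source may bear on it.

Series notes. In a toxicity assay on MRC5 cells (Homo sapiens) for inhibition, read by MTT assay, with a stated time of 72 h (a higher number here means a weaker inhibitor, a lower number a stronger inhibitor), compound 3 `O=C(Nc1cccc(OCc2cn(-c3ccc(Br)cc3)nn2)c1)Nc1ccc(Cl)c(C(F)(F)F)c1` gives 11000 nM, the second highest of the three numbers; compound 1 `N#Cc1ccccc1-n1cc(COc2cccc(NC(=O)Nc3ccc(Cl)c(C(F)(F)F)c3)c2)nn1` gives 17500 nM and compound 2 `O=C(Nc1cccc(OCc2cn(-c3ccc(F)cc3)nn2)c1)Nc1ccc(Cl)c(C(F)(F)F)c1` gives 4740 nM. The step to compound 4 `O=C(Nc1cccc(OCc2cn(-c3ccccc3C(F)(F)F)nn2)c1)Nc1ccc(Cl)c(C(F)(F)F)c1` is 2-(trifluoromethyl)phenyl in place of 4-bromophenyl on an aromatic nitrogen. Earlier steps at this aromatic nitrogen: a 3.7-fold lower number from compound 1 to compound 2 (0.57 log units; beyond the scatter), a 1.6-fold lower number from compound 1 to compound 3 (0.20 log units; within the scatter), and a 2.3-fold higher number from compound 2 to compound 3 (0.37 log units; beyond the scatter). Compound 1 with 2-cyanophenyl on that nitrogen gives 17500 nM, within the scatter of compound 3. For compound 4 the expected step is therefore a 1.2-fold higher number from compound 3 to compound 4 (0.07 log units; within the scatter), at most a small rise and possibly none beyond the scatter. The estimate for compound 4 in this assay is 13000 nM, with a range from 5000 nM to 35000 nM.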

Compound 4, half-maximal inhibitory concentration: 8230 nM
Compound 4: the middle estimate sits 1.6-fold (0.20 log units) above what was measured, and the stated range covers the measured number.
By their numbers in this assay, from the lowest: compounds 2, 4, 3 and 1 (each within the scatter of the next, the first and the last beyond it).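

In this assay, 2-(trifluoromethyl)phenyl on the aromatic nitrogen cannot be told apart from either 4-bromophenyl, with a 1.3-fold lower number from compound 3 to compound 4 (0.13 log units; within the scatter), or 4-fluorophenyl, with a 1.7-fold higher number from compound 2 to compound 4 (0.24 log units; within the scatter), even though those two groups differ beyond the scatter. Among the compounds shown here, with the substituent changed on an aromatic carbon, trifluoromethyl in place of cyano gives a 2.1-fold lower number from compound 1 to compound 4 (0.33 log units; beyond the scatter), the one new step beyond the scatter, though only a modest one. No measurement available here accounts for these steps.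

The compounds shown leave open how a phenyl ring carrying an amine or a carboxylic acid would read in this assay.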